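The source may report more compounds than this note shows. Statements on the series, on what has been measured and on what is new or still open speak of the compounds shown alone.

Compound 3 `COc1cc(C)cc2nc(N3CCN(C)CC3)oc12` carries a methoxy group on its aromatic ring, and in an assay on ileum (strain Hartley) with 5-hydroxytryptamine receptor 3A (Cavia porcellus) as the target (a lower number here means a smaller maximal response, a higher number a larger maximal response), compound 3 reaches 0.56. Among the compounds with values here, that is the highest of the three numbers measured so far. Compound 1 `CCc1cc(C)cc2nc(N3CCN(C)CC3)oc12`, which bears an ethyl group in the same place, gives 0.26 in this assay, and compound 2 `Cc1cc(Cl)cc2nc(N3CCN(C)CC3)oc12`, which carries a chloro group, gives 0.24. Within the data shown here, the one step measured between compounds differing in a single place is a number 0.30 higher from compound 1 to compound 3 (beyond the scatter), a rise beyond the scatter.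

Compound 4 `Cc1cc(C)c2oc(N3CCN(C)CC3)nc2c1` has not yet been measured. It differs from compound 3 as follows. methyl in place of methoxy on an aromatic carbon

Among the measured compounds shown here, the only step that bears on this change runs the other way: swapping a small alkyl group for methoxy raised the response by a number 0.30 higher from compound 1 to compound 3 (beyond the scatter). Replacing methoxy with methyl therefore points toward a fall of similar size, since compound 1 with ethyl gives 0.26 and compound 2 with methyl gives 0.24. Compound 4 is thus expected to give about 0.3 in this assay, within a range from 0.15 to 0.5. This estimate means a step of a number 0.26 lower from compound 3 to compound 4 (beyond the scatter), a drop beyond the scatter.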

Compound 4, intrinsic activity: the largest response reached, as a fraction of the reference agonist's: 0.62
Beside the measured number, compound 4's estimate is 0.32 below it; measured number outside the range, above it.
By their numbers in this assay, from the lowest: compounds 2 and 1 (each within the scatter of the next); then compounds 3 and 4 (each within the scatter of the next).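

The step a number 0.060 higher from compound 3 to compound 4 (within the scatter) shows that in this assay methoxy is not needed on this aromatic carbon, since a plain methyl group cannot be told apart from it. The low number at this position instead goes with the ethyl group: the step a number 0.36 higher from compound 1 to compound 4 (beyond the scatter), which shortens ethyl to methyl by putting hydrogen in place of the chain's end methyl, is large, so a small change to this group can shift the maximal response far. The step a number 0.38 higher from compound 2 to compound 4 (beyond the scatter), methyl in place of chloro, is also large, but it falls on the other substituted aromatic carbon, so the result at that second place is separate and shows that it too can move the response.

No measured evidence is available to explain either large step or the match between methyl and methoxy. As far as these compounds go, how a longer chain such as propyl, a hydroxyl group or an amine would behave on this aromatic carbon remains open, so it is unclear whether ethyl is an isolated case or the start of a trend with chain length.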